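This account rests on a few compounds, and the source may have more. Where it says the series, first, only, none or still open, it means among the compounds named here.

Measured compounds:
compound 1 `COc1cc(Cl)cc(-c2nn(-c3cccc(NC(=O)Nc4ccc(Cl)c(C(F)(F)F)c4)c3)cc2-c2ccncc2)c1` — 87%
compound 2 `COc1cc(Cl)cc(-c2nn(-c3cccc(NC(=O)Nc4cc(C(F)(F)F)cc(C(F)(F)F)c4)c3)cc2-c2ccncc2)c1` — 33%
compound 3 `COc1cc(Cl)cc(-c2nn(-c3cccc(NC(=O)Nc4ccc(Cl)c(Cl)c4)c3)cc2-c2ccncc2)c1` — 102%

In a functional assay on IGROV-1 cells (Homo sapiens) for inhibition, read by sulforhodamine B assay, with a stated time of 48 h, tested at 1 uM (a lower number here means a stronger effect, a higher number a weaker effect of the compound at the concentration tested), compound 1 stands second highest of the three numbers, so its effect at the tested concentration is modest. Its nearest neighbour is compound 3, whose number is higher, while compound 2 lies far lower and so shows the strongest effect of the three. For the measured compounds named here, the one measured step that changes the same outer ring, a number 15 percentage points higher from compound 1 to compound 3 (beyond the scatter), shows that swapping one halogen-type group for another there shifts the number by a modest amount beyond the scatter.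

Compound 4 `COc1cc(Cl)cc(-c2nn(-c3cccc(NC(=O)Nc4cccc(C(F)(F)F)c4)c3)cc2-c2ccncc2)c1` has not yet been measured. It differs from compound 1 in one place: hydrogen in place of chloro on an aromatic carbon. Going by the values given here, no measured step removes a group outright, so the comparison with compound 1 only suggests that losing a group on this ring is unlikely to strengthen the effect. The expected step, a number 7 percentage points higher from compound 1 to compound 4 (within the scatter), is therefore small and, if anything, upward. The estimate for compound 4 in this assay is 94%, with a range from 74% to 110%.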

Compound 4, a percentage reported as activity, at one concentration (the size of the read-out at that concentration, not a potency): 85%
The estimate for compound 4 lay 9 percentage points above the measured number; measured number inside the range.
By their numbers in this assay, from the lowest: compound 2; then compounds 4 and 1 (each within the scatter of the next); then compound 3.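

In this assay replacing the chloro group of the 4-chloro-3-(trifluoromethyl)phenyl ring with hydrogen gives no change that stands out from the scatter (a number 2 percentage points lower from compound 1 to compound 4 (within the scatter)), so at this position, with the trifluoromethyl group kept, the chloro group is not needed for the read-out. For the compounds shown here, the ring with only that trifluoromethyl group can still be told apart from the 3,4-dichlorophenyl ring (a number 17 percentage points lower from compound 3 to compound 4 (beyond the scatter)). A second trifluoromethyl group elsewhere on the ring counts for far more, as hydrogen in its place gives a large step (a number 52 percentage points higher from compound 2 to compound 4 (beyond the scatter)).

Nothing in the data explains why these changes differ so much in size. A methoxy group, a nitrile or an amine at the former chloro position could show whether this position accepts larger or different groups as readily as it accepts hydrogen.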